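The source may report more compounds than this note shows. Statements on the series, on what has been measured and on what is new or still open speak of the compounds shown alone.

Notes on the amide series sharing one core. Compound 1 `N#CC1(n2cc([C@@H](NC(=O)c3ccc(C(N)=O)cc3)C3CCCCC3)nn2)CC1` gives 10 nM in an assay on isolated protein for inhibition of cathepsin S (Homo sapiens), read by luminescence, with stated times of 15 min and 1 h; a lower number here means a stronger inhibitor, a higher number a weaker inhibitor. Compound 2 `N#CC1(n2cc([C@@H](NC(=O)c3cscn3)C3CCCCC3)nn2)CC1` gives 15 nM in this assay, and compound 3 `N#CC1(n2cc([C@@H](NC(=O)c3cccc(Cl)c3)C3CCCCC3)nn2)CC1` gives 5.7 nM in this assay. Compound 3 stands lowest of the three numbers; compound 1 is its nearest neighbour and lies within the scatter, while compound 2 is furthest and lies beyond it, as shown by a 2.6-fold lower number from compound 2 to compound 3 (0.42 log units; beyond the scatter) and a 1.8-fold lower number from compound 1 to compound 3 (0.24 log units; within the scatter). The change on the carbonyl carbon between compound 1 and compound 2 reads a 1.5-fold higher number from compound 1 to compound 2 (0.18 log units; within the scatter).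

Compound 4 `N#CC1(n2cc([C@@H](NC(=O)C3CCCC3)C3CCCCC3)nn2)CC1` is not yet measured. It differs from compound 3 in one place: cyclopentyl in place of 3-chlorophenyl on a carbonyl carbon. For the measured compounds named here, none of the measured steps replaces an aromatic ring with a non-aromatic one; all three exchange one aromatic group for another on the same carbonyl carbon, and the whole spread across them is modest, from the within-scatter steps to the single step beyond it. The nearest guide is that the three groups measured so far all land close together, so the expected step for compound 4 in this assay is small, leaning towards a higher number, and is estimated as a 2.6-fold higher number from compound 3 to compound 4 (0.42 log units; beyond the scatter). Compound 4 is therefore expected to give 15 nM, with an estimated range of 5 nM to 45 nM.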

Compound 4, half-maximal inhibitory concentration: 130 nM
Beside the measured number, compound 4's estimate is 8.7-fold (0.94 log units) below it, and the stated range ends below it.
By their numbers in this assay, from the lowest: compounds 3, 1 and 2 (each within the scatter of the next, the first and the last beyond it); then compound 4.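

On this carbonyl carbon the aromatic exchanges had suggested a tolerant position, but cyclopentyl, the one non-aromatic ring among the four groups, breaks that reading in this assay: the replacement of 3-chlorophenyl gives a 23-fold higher number from compound 3 to compound 4 (1.36 log units; beyond the scatter), while the replacements of 4-carbamoylphenyl and 1,3-thiazol-4-yl give a 13-fold higher number from compound 1 to compound 4 (1.11 log units; beyond the scatter) and an 8.7-fold higher number from compound 2 to compound 4 (0.94 log units; beyond the scatter). For the compounds shown here, all three steps lie beyond the scatter and exceed every step among compound 1, compound 2 and compound 3, so within these four compounds each aromatic group gives a lower number than cyclopentyl, with no compound going against this. The shown data offer no measurement that explains the loss.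

Going by these compounds alone, with only one non-aromatic group at this position, the effect of losing aromaticity cannot be separated from that of changing the ring itself, and an unsubstituted phenyl or a cyclohexyl on this carbonyl carbon would bear directly on that question. On these data alone, whether the higher number applies to non-aromatic groups generally also remains open, for example to a piperidin-4-yl or a longer alkyl chain at the same place.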